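The compounds below may be only part of what the source reports. "The series", "measured", "known", "first", "only" and "open" are said of these compounds alone.

Working notes on the series. Compound 1 `COc1c(NC(=O)c2cc3cccc(NC(=O)c4ccc(NC5CC5)nc4)c3s2)cc(C(C)(C)C)cc1NS(C)(=O)=O` and compound 2 `COc1c(NC(=O)c2cc3cccc(NC(=O)c4cccnc4)c3n2C)cc(C(C)(C)C)cc1NS(C)(=O)=O` share the same core and have both been run in an in vivo ADME assay on the whole organism (strain Sprague-Dawley) for pharmacokinetics, with Rattus norvegicus as the target, at a dose of 1 mg/kg by the intravenous route; a higher number here means faster removal of the compound, a lower number slower removal. Compound 1 gives 4 mL/min/kg in this assay, and compound 2 gives 3 mL/min/kg; the two numbers sit within the scatter of each other, so no order between them can be read off. Compound 3 `COc1c(NC(=O)c2cc3cccc(NC(=O)c4cccnc4)c3s2)cc(C(C)(C)C)cc1NS(C)(=O)=O` is not yet measured in this assay. It differs from compound 1 in one place: hydrogen in place of cyclopropylamino on an aromatic carbon, which leaves a pyridin-3-yl carbonyl as in compound 2. Both measured values are low, and nothing among them indicates a step beyond the scatter for this change, so the expected step from compound 1 to compound 3 is no change at the digits printed from compound 1 to compound 3 (within the scatter), that is, essentially none beyond the scatter. Compound 3 is therefore estimated at 4 mL/min/kg in this assay, with a range from 2 mL/min/kg to 9 mL/min/kg.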

Compound 3, clearance: 19 mL/min/kg
Beside the measured number, compound 3's estimate is 4.8-fold (0.68 log units) below it; the measured number lies above the stated range.
By their numbers in this assay, from the lowest: compounds 2 and 1 (each within the scatter of the next); then compound 3.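

In this assay, the cyclopropylamino group on the aromatic carbon next to the ring nitrogen is not a silent substituent on the core of compound 1: hydrogen in its place gives a 4.8-fold higher number from compound 1 to compound 3 (0.68 log units; beyond the scatter), a step that the two earlier compounds, which differ in more than one place, could not reveal. Compound 2 carries the same pyridin-3-yl carbonyl without that group and gives 3 mL/min/kg, so the unsubstituted ring does not go with the higher number on every core. No measurement at hand bears on what lies behind this step.

As far as these compounds go, it remains open whether a smaller group at this position, such as a methoxy or a simple amine, would keep the number as low as cyclopropylamino does. Also open, from the compounds shown here alone, is whether adding cyclopropylamino to the ring of compound 2 would change its number at all.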